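Compound 3 to compound 4: a furan-2-yl swap

The compounds below may be only part of what the source reports. "The series", "measured", "known", "first", "only" and "open" are said of these compounds alone.

Measured in a functional assay on SGC-7901 cells (Homo sapiens) for antiproliferative activity, read by MTT assay, with a stated time of 48 h; a higher number here means a weaker inhibitor, a lower number a stronger inhibitor
compound 1 `Cc1ccccc1-c1nnc(SCc2ccc(Cl)nc2)o1` gives 8.51 ug/mL
compound 2 `Clc1ccc(-c2nnc(SCc3ccc(Cl)nc3)o2)cc1` gives 8.62 ug/mL
compound 3 `Nc1ccc(-c2nnc(SCc3ccc(Cl)nc3)o2)cc1` gives 8.48 ug/mL

Compound 3 stands level with the other two compounds in this assay, and its gaps to them lie within the scatter. The next compound is compound 4 `Clc1ccc(CSc2nnc(-c3ccco3)o2)cn1`, which carries furan-2-yl in place of 4-aminophenyl on an aromatic carbon. Three measured steps change the group at this same place: a 1.0-fold higher number from compound 1 to compound 2 (0.01 log units; within the scatter), a 1.0-fold lower number from compound 1 to compound 3 (0.00 log units; within the scatter) and a 1.0-fold lower number from compound 2 to compound 3 (0.01 log units; within the scatter). All three lie within the scatter, so the three groups tried so far give no separation. None of these steps brings in a five-membered aromatic ring at this place, so the data do not test the change directly, and the range is kept wide. The expected step is a 1.0-fold higher number from compound 3 to compound 4 (0.00 log units; within the scatter), with no shift beyond the scatter expected in either direction. Compound 4 is expected at 8.5 ug/mL within an estimated range of 4.5 ug/mL to 16 ug/mL in this estimate.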

Compound 4, half-maximal inhibitory concentration: 14.3 ug/mL
The estimate for compound 4 lay 1.7-fold (0.23 log units) below the measured number; low and high end bracket the measured number.
By their numbers in this assay, from the lowest: compounds 3, 1, 2 and 4 (each within the scatter of the next).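

Across this assay, a 1.7-fold higher number from compound 3 to compound 4 (0.23 log units; within the scatter) and a 1.7-fold higher number from compound 2 to compound 4 (0.22 log units; within the scatter) and also a 1.7-fold higher number from compound 1 to compound 4 (0.23 log units; within the scatter) show that furan-2-yl, the first five-membered aromatic ring at this place, does not separate from the three groups built on a six-membered aromatic ring of carbon only. The series now spans both ring sizes here, and with 4-aminophenyl gone the amino donor is also absent, yet all four compounds remain within the scatter of one another. No evidence accompanies this result that could bear on it.

As far as these compounds go, whether a carboxylic acid, a morpholine ring or a longer alkyl chain on this carbon would give a step beyond the scatter stays open. The compounds shown also leave open whether any group at this place can shift the number in this assay at all.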